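A Methoxypyridine Swap on the Amide Carbonyl

The compounds below may be only part of what the source reports. "The series", "measured", "known", "first", "only" and "open" are said of these compounds alone.

In a functional assay on MDA-MB-231 cells (Homo sapiens) for antiproliferative activity, read by MTT assay, with a stated time of 24 h (a lower number here means a stronger inhibitor, a higher number a weaker inhibitor), compound 2 `COC(=O)c1scc(-c2ccc(NC(=O)c3ccc(F)c(Cl)n3)cc2)c1OC` gives 10300 nM. Compound 3 `COC(=O)c1scc(-c2ccc(NC(=O)c3ccc(C(F)(F)F)cc3Br)cc2)c1OC` gives 19600 nM, which lies within the usual scatter of the value for compound 2. Compound 1 `COC(=O)c1scc(-c2ccc(NC(=O)c3cccc(C(F)(F)F)c3)cc2)c1OC` gives 24600 nM. Compound 4 `COC(=O)c1scc(-c2ccc(NC(=O)c3ccc(OC)nc3)cc2)c1OC` has 6-methoxypyridin-3-yl in place of 6-chloro-5-fluoropyridin-2-yl on a carbonyl carbon. Among the measured compounds shown here, the one measured step at this carbonyl, a 2.4-fold lower number from compound 1 to compound 2 (0.38 log units; beyond the scatter), is modest. A small step is therefore expected in this assay, perhaps no larger than the scatter, and tentatively toward a higher number, since no methoxy group has been measured yet. The expected change is a 1.6-fold higher number from compound 2 to compound 4 (0.19 log units; within the scatter). For compound 4, the estimated value is 16000 nM, with an expected range from 7000 nM to 35000 nM.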

Compound 4, half-maximal inhibitory concentration: 15300 nM
Beside the measured number, compound 4's estimate is 1.0-fold (0.02 log units) above it, within the range that was stated.
By their numbers in this assay, from the lowest: compounds 2, 4, 3 and 1 (each within the scatter of the next, the first and the last beyond it).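

In this assay, 6-methoxypyridin-3-yl on this carbonyl carbon cannot be told apart from either earlier group: the steps are (a 1.5-fold higher number from compound 2 to compound 4 (0.17 log units; within the scatter)) and (a 1.6-fold lower number from compound 1 to compound 4 (0.21 log units; within the scatter)), both within the scatter. Compound 4 therefore shows that this position tolerates a methoxy group on the ring without a step beyond the scatter. It also shows that a pyridine ring here does not by itself give a clear step from compound 1. Whether an amine or a carboxylic acid on this ring would move the number further remains open, and no measurement shown explains these numbers.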